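Swapping the Aryl Group on the Carbamoyl of Compound 3

This account rests on a few compounds, and the source may have more. Where it says the series, first, only, none or still open, it means among the compounds named here.

Compound 1 `CN1CCN(c2ccc(-c3cc4c(N5CCN(S(=O)(=O)C6CC6)CC5)ncnc4s3)cc2)CC1`: 11500 nM
Compound 2 `CN1CCN(c2ccc(-c3cc4c(N5CCN(C(=O)Nc6ccc(C#N)cc6)CC5)ncnc4s3)cc2)CC1`: 3930 nM
Compound 3 `CN1CCN(c2ccc(-c3cc4c(N5CCN(C(=O)Nc6ccc(Cl)cc6)CC5)ncnc4s3)cc2)CC1`: 5440 nM

In a functional assay on MDA-MB-231 cells (Homo sapiens) for antiproliferative activity, read by MTT assay, with a stated time of 48 h (on this read-out higher numbers stand for weaker inhibition and lower numbers for stronger inhibition), compound 3 gives 5440 nM, a value that cannot be told apart from that of compound 2. The step there is a 1.4-fold higher number from compound 2 to compound 3 (0.14 log units; within the scatter). The clear gaps lie on the side of compound 1, with a 2.1-fold lower number from compound 1 to compound 3 (0.33 log units; beyond the scatter) and a 2.9-fold lower number from compound 1 to compound 2 (0.47 log units; beyond the scatter).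

Compound 4 `CC(C)c1cccc(C(C)C)c1NC(=O)N1CCN(c2ncnc3sc(-c4ccc(N5CCN(C)CC5)cc4)cc23)CC1` keeps the carbamoyl link of compound 3 and changes only the aromatic group on it: 2,6-diisopropylphenyl in place of 4-chlorophenyl on an amide-type nitrogen. In words, 2,6-diisopropylphenyl stands in place of 4-chlorophenyl on an amide-type nitrogen.

The closest guide is the change on that same aromatic group, a 1.4-fold higher number from compound 2 to compound 3 (0.14 log units; within the scatter). Within the data shown here, it is a much smaller swap, and no measured compound carries the new group, so this guide is weak. No shift beyond the scatter is therefore expected in this assay, though with wide uncertainty. The expected step is a 1.1-fold higher number from compound 3 to compound 4 (0.04 log units; within the scatter). For compound 4 the estimated value is 6000 nM, with an expected range from 2000 nM to 18000 nM.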

Compound 4, half-maximal inhibitory concentration: 8430 nM
For compound 4 the middle estimate is 1.4-fold (0.15 log units) below the measured one, and the stated range covers the measured number.
By their numbers in this assay, from the lowest: compounds 2, 3, 4 and 1 (each within the scatter of the next, the first and the last beyond it).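

This position accepts 2,6-diisopropylphenyl, with 12 heavy atoms, in place of 4-chlorophenyl, with 7, and in this assay this swap gives a 1.5-fold higher number from compound 3 to compound 4 (0.19 log units; within the scatter). So a much heavier aromatic group on the amide-type nitrogen stays level with the chloro compound, yet the same group, compared with the 4-cyanophenyl of compound 2, gives a 2.1-fold higher number from compound 2 to compound 4 (0.33 log units; beyond the scatter), a modest step and the first one beyond the scatter among changes to this aromatic group. Nothing measured here explains either step.

Still open, from the compounds shown here alone, is whether an aromatic ring is needed on this nitrogen at all, which a cyclohexyl group or a simple methyl would test. Also open, going by these compounds, is how a group carrying an amine or a carboxylic acid would behave at this position.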